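Fluoro for Chloro: Expecting the Value of Compound 4

The source may report more compounds than this note shows. Statements on the series, on what has been measured and on what is new or still open speak of the compounds shown alone.

Measured so far in an assay on cells for inhibition of Palmitoleoyl-protein carboxylesterase NOTUM variant C330S (Homo sapiens), read by fluorescence, with a stated time of 40 min; on this read-out lower numbers stand for stronger inhibition and higher numbers for weaker inhibition:
compound 1, `Cc1cc(C(=O)O)c(C)n1-c1ccc(F)cc1`: 1900 nM
compound 2, `Cc1cc(C(=O)O)c(C)n1-c1ccc(Cl)cc1`: 860 nM
compound 3, `Cc1cc(C(=O)O)c(C)n1-c1cccc(Cl)c1Cl`: 220 nM

Compound 3 gives the lowest of the three numbers in this assay; the difference between its core and that of compound 2 is not broken down here. Between compound 2 and compound 1 one change is made, (fluoro in place of chloro on an aromatic carbon), and it gives a 2.2-fold higher number from compound 2 to compound 1 (0.34 log units; beyond the scatter).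

Compound 4, `Cc1cc(C(=O)O)c(C)n1-c1cccc(Cl)c1F`, has not yet been measured. It differs from compound 3 by fluoro in place of chloro on an aromatic carbon. This is the same kind of change as from compound 2 to compound 1, but its surroundings differ: in compound 1 the fluoro sits para to a large group, while in compound 4 it sits ortho to a chloro group (1 heavy atom) and ortho to a large group.

On the strength of a 2.2-fold higher number from compound 2 to compound 1 (0.34 log units; beyond the scatter) the step of a 2.0-fold higher number from compound 3 to compound 4 (0.31 log units; beyond the scatter) is expected to be of a similar modest size and in the same direction. Compound 4 is therefore estimated at 450 nM, with a likely range from 200 nM to 1000 nM.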

Compound 4, half-maximal inhibitory concentration: 380 nM
Estimate against measurement, compound 4: 1.2-fold (0.07 log units) above, and the stated range covers the measured number.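

In this assay, putting fluoro in place of chloro on the core of compound 3 gives a 1.7-fold higher number from compound 3 to compound 4 (0.24 log units; within the scatter), so this step alone does not separate compound 3 from compound 4. Set beside the earlier step, the same change reads alike on both cores: the same change on two cores in this assay, a 2.2-fold higher number (0.34 log units; beyond the scatter) from compound 2 to compound 1 and a 1.7-fold higher number (0.24 log units; within the scatter) from compound 3 to compound 4, 1.3-fold (0.11 log units) apart, within the scatter of two such steps. Going by these compounds alone, this shows that the size of the step carried over from one core to the other, with the chloro and fluoro groups in different surroundings, but it does not establish a rule for the series, as it rests on only two pairs and the second step on its own cannot fix a direction.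

The compounds shown leave open whether the step would hold on a core in which an amide or a nitrile stands in place of the carboxylic acid. They also leave open how bromo, methoxy or trifluoromethyl would compare with chloro and fluoro on the same carbon.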